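Chloro Added to a Naphthalene Diester Core

A few compounds are considered here, and "the series" means these few. Any claim that something is new, unique, unknown or untested is made for them only; others in the source may bear on it.

Of the compounds shown here, three have been measured in a physicochemical assay for lipophilicity; on this read-out higher numbers stand for higher lipophilicity and lower numbers for lower lipophilicity. Compound 1 `COc1c(OC)c(OC(C)=O)c2ccccc2c1OC(C)=O` gives 2.39. Compound 3 `COc1c(OC)c(OC(C)=O)c2c(Cl)cccc2c1OC(C)=O` gives 3.16, and the step of a number 0.77 log units higher from compound 1 to compound 3 (beyond the scatter) arises from the change (chloro in place of hydrogen on an aromatic carbon). Compound 2 `COc1c(OC)c(OC(=O)C(C)(C)C)c2ccccc2c1OC(=O)C(C)(C)C` gives 5.69, the highest of the three numbers; how the core of compound 2 differs from that of compound 1 is not broken down here.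

Compound 4 `COc1c(OC)c(OC(=O)C(C)(C)C)c2cc(Cl)ccc2c1OC(=O)C(C)(C)C` has not yet been measured in this assay. It differs from compound 2 by chloro in place of hydrogen on an aromatic carbon. Going by the values given here, this is the same kind of change as the one from compound 1 to compound 3, but not the same change: in compound 3 the chloro sits ortho to a fused ring and meta to a fused ring, whereas in compound 4 it sits meta to a fused ring and para to a fused ring.

Resting on the step of a number 0.77 log units higher from compound 1 to compound 3 (beyond the scatter), the step from compound 2 to compound 4 in this assay is expected to be a number 0.71 log units higher from compound 2 to compound 4 (beyond the scatter). Compound 4 is thus estimated to give about 6.4, with a range from 5.9 to 6.9.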

Compound 4, partition coefficient: 6.6
Estimate against measurement, compound 4: 0.20 log units below, within the range that was stated.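

In this assay, chloro in place of hydrogen on an aromatic carbon gives a number 0.91 log units higher from compound 2 to compound 4 (beyond the scatter), and this runs the same way as a number 0.77 log units higher from compound 1 to compound 3 (beyond the scatter), so in both of these pairs the change carries a rise beyond the scatter. This rests on just two pairs, and the two steps differ in the core as well as in the place of the chloro, which in compound 4 is meta to a fused ring and para to a fused ring and in compound 3 is elsewhere, so the effect of the core cannot be separated from that of the position. No measurement offered here bears on why the step has the size it has.

The compounds shown leave open what chloro would do at one and the same place on both cores. They also leave open whether an amine or a carboxylic acid in that place, or a longer chain on the esters, would carry from one core to the other in the same way.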